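Urea aryl swap: dichlorophenyl to trifluoromethylphenyl

The source may report more compounds than this note shows. Statements on the series, on what has been measured and on what is new or still open speak of the compounds shown alone.

Compound 3 `COc1cc(Cl)cc(-c2nn(-c3cccc(NC(=O)Nc4ccc(Cl)c(Cl)c4)c3)cc2-c2ccncc2)c1` is the reference point. In a functional assay on CCRF-CEM cells (Homo sapiens) for inhibition, read by sulforhodamine B assay, with a stated time of 48 h, tested at 0.01 uM (on this read-out higher numbers stand for a weaker effect at the one concentration tested and lower numbers for a stronger effect), compound 3 gives 97%, level with compound 1 `COc1cc(Cl)cc(-c2nn(-c3cccc(NC(=O)Nc4ccc(Cl)c(C(F)(F)F)c4)c3)cc2-c2ccncc2)c1`, which in this assay gives 97%; together they are the highest of the three numbers. Compound 2 `COc1cc(Cl)cc(-c2nn(-c3cccc(NC(=O)Nc4cc(C(F)(F)F)cc(C(F)(F)F)c4)c3)cc2-c2ccncc2)c1` in this assay gives 87%, and that gap to compound 3 lies within the scatter. Among the compounds with values here, the one measured step bearing on the urea aryl group, no change at the digits printed from compound 1 to compound 3 (within the scatter), shows that exchanging a single halogen-type substituent on that ring moves nothing. Compound 4 `COc1cc(Cl)cc(-c2nn(-c3cccc(NC(=O)Nc4cccc(C(F)(F)F)c4)c3)cc2-c2ccncc2)c1` carries the change (3-(trifluoromethyl)phenyl in place of 3,4-dichlorophenyl on an amide-type nitrogen). This removes one chlorine and trades the other for trifluoromethyl, a substituent already present in compound 1 and twice in compound 2, both of which sit within the scatter of compound 3. No step beyond the scatter is therefore expected in this assay for compound 4; the estimated step of a number 4 percentage points lower from compound 3 to compound 4 (within the scatter) is flat. Compound 4 is expected to give about 93%, in the range 82% to 100%.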

Compound 4, a percentage reported as activity, at one concentration (the size of the read-out at that concentration, not a potency): 98%
Beside the measured number, compound 4's estimate is 5 percentage points below it; low and high end bracket the measured number.
By their numbers in this assay, from the lowest: compounds 2, 1, 3 and 4 (each within the scatter of the next, the first and the last beyond it).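

In this assay there is no shift a number 1 percentage points higher from compound 3 to compound 4 (within the scatter) and none a number 1 percentage points higher from compound 1 to compound 4 (within the scatter) so on the amide-type nitrogen a 3-(trifluoromethyl)phenyl group reads the same as the two-substituent rings of these neighbours. Within the data shown here, the one step beyond the scatter is modest, a number 11 percentage points higher from compound 2 to compound 4 (beyond the scatter) and it is the first sign that this ring can move the read-out at all, since loss of a trifluoromethyl group separates this pair while compound 1 and compound 3 stay within the scatter of compound 4. No accompanying measurement explains these steps.

From the compounds shown here alone, whether a carboxylic acid or an amine on this phenyl ring, or a longer alkyl chain in place of the ring, would move the read-out stays open. A reading at one concentration also tells only whether the effect is stronger or weaker at that concentration.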